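A Benzothiazole in Place of the Difluorophenyl Group

The source may hold more compounds than are shown below. What is called first, only, known or untested is meant among the compounds shown, and "the series" means these compounds.

Of the compounds shown here, three have so far been tested in a functional assay on HCT-116 cells (Homo sapiens) for inhibition, read by colorimetric assay, with a stated time of 3 days; a lower number here means a stronger inhibitor, a higher number a weaker inhibitor. Compound 1, `O=C(CCCCCCNC(=O)C(O)(O)C(F)(F)F)Nc1ccc(F)cc1F`, gives 18500 nM in this assay. Compound 2, `COc1cc(NC(=O)CCCCCCNC(=O)C(O)(O)C(F)(F)F)cc(OC)c1OC`, gives 14100 nM. Compound 1 has the higher of the two numbers, but the gap to compound 2 lies within the scatter, so the two cannot be told apart. Compound 3, `CC(=O)C(=O)NCCCCC(=O)Nc1ccccc1`, gives only > 100000 nM in this assay, which is a limit of the assay rather than a number. This is the limit of > 100000 nM in this assay, at which 1 of the 3 values shown sits.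

The next compound, compound 4, `O=C(CCCCCCNC(=O)C(O)(O)C(F)(F)F)Nc1nc2ccccc2s1`, keeps the long chain and the amide carbonyl of compound 1 and changes only the group on the amide-type nitrogen: 1,3-benzothiazol-2-yl in place of 2,4-difluorophenyl on an amide-type nitrogen.

Within the data shown here, no pair of measured compounds differs in one place, so there is no measured step to guide the size or direction of this change. The two compounds that gave numbers, compound 1 and compound 2, sit within the scatter of each other despite different aromatic groups on the same nitrogen. On that basis the expected step of a 1.2-fold lower number from compound 1 to compound 4 (0.09 log units; within the scatter) is small, with no clear direction beyond the scatter. Compound 4 is therefore estimated at 15000 nM in this assay, with a likely range from 4000 nM to 60000 nM.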

Compound 4, half-maximal inhibitory concentration: 2370 nM
For compound 4 the middle estimate is 6.3-fold (0.80 log units) above the measured one; measured number outside the range, below it.
By their numbers in this assay, from the lowest: compound 4; then compounds 2 and 1 (each within the scatter of the next). At a limit, above all of these: compound 3.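

Putting 1,3-benzothiazol-2-yl in place of 2,4-difluorophenyl on the amide-type nitrogen gives a 7.8-fold lower number from compound 1 to compound 4 (0.89 log units; beyond the scatter) in this assay, so the group at this position can shift the number by more than the scatter, with the long chain and the amide carbonyl kept the same. This single swap alters several things at once: a single six-membered ring of carbon only gives way to a pair of fused rings, the two fluorine atoms leave, a ring nitrogen and a ring sulfur enter, and the count of hydrogen-bond acceptors on the group rises from 0 to 2. Nothing measured among these compounds bears on which of these differences lies behind the lower number.

The compounds shown leave open which feature of the new group carries the step: a 1,3-benzoxazol-2-yl group, with oxygen in place of the ring sulfur, or a naphthyl group, with carbon atoms only, would help to separate them. Among these compounds, they also leave open whether 1,3-benzothiazol-2-yl gives a similar step on a shorter or a longer chain than the one compound 1 and compound 4 share.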